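Aziridinylquinone series: side-chain variation at the ring carbon

The compounds below may be only part of what the source reports. "The series", "measured", "known", "first", "only" and "open" are said of these compounds alone.

Measured so far:
compound 1 `CC1=C(N2CC2)C(=O)C(C(C)COC(N)=O)=C(N2CC2)C1=O` — 6.41
compound 2 `COC(CO)C1=C(N2CC2)C(=O)C(C)=C(N2CC2)C1=O` — 6.9

Among the compounds with values here, in a functional assay on L1210 cells (Mus musculus), with a stated time of 12 days (on this read-out lower numbers stand for lower potency and higher numbers for higher potency (the scale is a negative logarithm)), compound 2 gives the higher of the two numbers; the one measured step, a number 0.49 log units higher from compound 1 to compound 2 (beyond the scatter), is modest but beyond the scatter. Compound 3 `COCCC1=C(N2CC2)C(=O)C(C)=C(N2CC2)C1=O` carries the change (2-methoxyethyl in place of 2-hydroxy-1-methoxyethyl on a double-bonded ring carbon). Within the data shown here, no measured step covers a change of this kind on the side chain, so the step from compound 1 to compound 2 is only a loose guide. The expected step is therefore small, a number 0.20 log units lower from compound 2 to compound 3 (within the scatter), and within the scatter. Compound 3 is estimated at 6.7, range 6.2 to 7.2.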

Compound 3, logarithm of the reciprocal of the active concentration, log(1/C): 5.57
Compound 3: the middle estimate sits 1.13 log units above what was measured; measured number below the stated range.
By their numbers in this assay, from the lowest: compound 3; then compound 1; then compound 2.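

In this assay, the side chain on this double-bonded ring carbon proves more sensitive than the earlier step showed: 2-methoxyethyl in place of 2-hydroxy-1-methoxyethyl gives a large drop (a number 1.33 log units lower from compound 2 to compound 3 (beyond the scatter)). The smaller group of compound 3 also falls short of the longer group of compound 1 (a number 0.84 log units lower from compound 1 to compound 3 (beyond the scatter)), leaving compound 3 lowest of the three. Nothing measured here accounts for the drop.

The step to compound 3 changes the hydroxy group and the branch together, and the compounds shown do not separate them. Open, on these data alone, is whether a 2-hydroxyethyl or 2-aminoethyl chain would hold the number of compound 2.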